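Swapping the aryl group on a weak sulfonamide

A few compounds are considered here, and "the series" means these few. Any claim that something is new, unique, unknown or untested is made for them only; others in the source may bear on it.

Values in a functional assay on HeLa cells (Homo sapiens) for cytotoxicity, read by sulforhodamine B assay (a higher number here means a weaker inhibitor, a lower number a stronger inhibitor), for the measured compounds
Compound 1 `Cc1ccc(S(=O)(=O)NC(C2=CC(=O)c3c(O)ccc(O)c3C2=O)C(C)C)cc1` gives 4850 nM
Compound 2 `COc1ccc(S(=O)(=O)NC(C2=CC(=O)c3c(O)ccc(O)c3C2=O)C(C)C)c(OC)c1` gives 2750 nM
Compound 3 `COc1ccc(S(=O)(=O)NC(C)C2=CC(=O)c3c(O)ccc(O)c3C2=O)c(OC)c1` gives 19500 nM

Compound 3 is the weakest inhibitor of the three, and its number lies beyond the scatter from those of compound 1 and compound 2. Compound 4 `CC(NS(=O)(=O)c1cccc(Br)c1)C1=CC(=O)c2c(O)ccc(O)c2C1=O` has not been measured. It carries 3-bromophenyl in place of 2,4-dimethoxyphenyl on a sulfonyl sulfur.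

Among the measured compounds shown here, only one measured step changes the group on that sulfur: a 1.8-fold lower number from compound 1 to compound 2 (0.25 log units; within the scatter). It was seen with isopropyl on the chain carbon, not with the methyl of compound 3. The larger step, a 7.1-fold higher number from compound 2 to compound 3 (0.85 log units; beyond the scatter), came from methyl in place of isopropyl, a change not made here. For the measured compounds named here, no measured compound yet carries 3-bromophenyl, so the expectation is loose, but no step beyond the scatter is expected in this assay. The estimated step is a 1.3-fold lower number from compound 3 to compound 4 (0.11 log units; within the scatter). For compound 4 the expected value is 15000 nM, with an estimated range of 6000 nM to 40000 nM.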

Compound 4, half-maximal inhibitory concentration: 6350 nM
Estimate against measurement, compound 4: 2.4-fold (0.37 log units) above; measured number inside the range.
By their numbers in this assay, from the lowest: compounds 2, 1 and 4 (each within the scatter of the next, the first and the last beyond it); then compound 3.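

The group on the sulfonyl sulfur can matter in this assay: with methyl on the chain carbon, 3-bromophenyl in place of 2,4-dimethoxyphenyl gives a 3.1-fold lower number from compound 3 to compound 4 (0.49 log units; beyond the scatter). The earlier change at this sulfur, a 1.8-fold lower number from compound 1 to compound 2 (0.25 log units; within the scatter), stayed within the scatter, but it had isopropyl on the chain carbon and a different outgoing group, 4-methylphenyl, so these two steps do not show whether the chain carbon's substituent alters the effect of the aryl group. Nothing available here explains the gain seen with 3-bromophenyl.

Still open, from the compounds shown here alone, is whether 3-bromophenyl would give a comparable step with isopropyl on the chain carbon. The compounds shown also leave open how an aryl ring carrying an amine or a carboxylic acid, or a longer chain on the chain carbon, would read in this assay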